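Vero cytotoxicity notes: two amides measured, a third pending

The compounds below may be only part of what the source reports. "The series", "measured", "known", "first", "only" and "open" are said of these compounds alone.

Compound 1 `COC(=O)c1cc(-c2cccc(NC(=O)c3ccc(OCc4ccc(Cl)cc4)cc3)c2)on1` gives > 80 ug/mL in an ADME assay on Vero cells (Chlorocebus sabaeus) for cytotoxicity, read by MTT assay, with a stated time of 72 h (on this read-out lower numbers stand for higher toxicity in this test and higher numbers for lower toxicity in this test), a limit of the assay rather than a number.
Compound 2 `COC(=O)c1cc(-c2cccc(NC(=O)c3ccc(/C=C/C(=O)c4cccc(Cl)c4)cc3)c2)on1` gives > 2.5 ug/mL in this assay, again a limit of the assay.

Compound 2 thus stands at a limit, (the limit of > 2.5 ug/mL in this assay, at which 1 of the 2 values shown sits). Compound 1 stands at a different limit, (the limit of > 80 ug/mL in this assay, at which 1 of the 2 values shown sits). Among the compounds with values here, the one measured step, a step that the two limits leave unreadable from compound 1 to compound 2, has both of its ends at limits and yields no size. Compound 3 `COC(=O)c1cc(-c2cccc(NC(=O)c3ccc(/C=C/C(=O)c4ccc(CC(C)C)cc4)cc3)c2)on1` differs from compound 2 by 4-isobutylphenyl in place of 3-chlorophenyl on a carbonyl carbon. Within the data shown here, no measured step touches this carbonyl carbon, so none bears directly on the change, and the unreadable step between compound 1 and compound 2 supplies no guidance on its size. The step that the limit leaves unreadable from compound 2 to compound 3 is therefore expected to be modest, with no direction claimed beyond the scatter. Compound 3 is expected to give about 30 ug/mL in this assay, within the range 5 ug/mL to 100 ug/mL, and a limit rather than a number is quite possible.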

Compound 3, half-maximal cytotoxic concentration: > 10 ug/mL
Compound 3: only a limit was reported; the forecaster's own chance of this, stated with the estimate: 50%; the middle value lies beyond the limit too.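

Compound 2 and compound 3 both stand at limits in this assay, so no step can be read between them. Still open, going by these compounds, is the actual half-maximal cytotoxic concentration of compound 1, compound 2 and compound 3, and whether 4-isobutylphenyl in place of 3-chlorophenyl changes it.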